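Swapping the oxygen substituent of compound 3 for allyl

A few compounds are considered here, and "the series" means these few. Any claim that something is new, unique, unknown or untested is made for them only; others in the source may bear on it.

Measured in a functional assay on U-937 cells (Homo sapiens) for cytotoxicity, read by MTT assay, with a stated time of 24 h; a higher number here means a weaker inhibitor, a lower number a stronger inhibitor:
compound 1 `BrCCCCOc1c(Br)cc(Br)cc1Oc1ccc(Br)cc1Br` gives 29 ug/mL
compound 2 `OCCCOc1c(Br)cc(Br)cc1Oc1ccc(Br)cc1Br` gives 32.3 ug/mL
compound 3 `CC(C)(C)C(=O)C(C#N)Oc1c(Br)cc(Br)cc1Oc1ccc(Br)cc1Br` gives 32.5 ug/mL

At 32.5 ug/mL compound 3 cannot be told apart from the other two compounds. Compound 4 `C=CCOc1c(Br)cc(Br)cc1Oc1ccc(Br)cc1Br` carries allyl in place of cyano((tert-butyl)carbonyl)methyl on an oxygen on an aromatic ring. Two measured steps exchange the group on this same oxygen, a 1.1-fold higher number from compound 1 to compound 3 (0.05 log units; within the scatter) and a 1.0-fold higher number from compound 2 to compound 3 (0.00 log units; within the scatter), and a third alters the chain, a 1.1-fold higher number from compound 1 to compound 2 (0.05 log units; within the scatter). Within the data shown here, all three lie within the scatter, though no measured compound carries allyl. No step beyond the scatter is therefore expected in this assay, in either direction. The estimated step is a 1.0-fold lower number from compound 3 to compound 4 (0.02 log units; within the scatter) and is expected to stay within the scatter. Compound 4 is estimated at 31 ug/mL (16 ug/mL to 55 ug/mL) .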

Compound 4, half-maximal inhibitory concentration: 29 ug/mL
Beside the measured number, compound 4's estimate is 1.1-fold (0.03 log units) above it, and the stated range covers the measured number.
By their numbers in this assay, from the lowest: compounds 1, 4, 2 and 3 (each within the scatter of the next).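

Compound 4 shows that in this assay this oxygen tolerates a far smaller group: a 1.1-fold lower number from compound 3 to compound 4 (0.05 log units; within the scatter), as allyl with 3 heavy atoms and 0 hydrogen-bond acceptors replaces cyano((tert-butyl)carbonyl)methyl with 9 heavy atoms and 2 hydrogen-bond acceptors. The chain exchanges read the same way, with vinyl in place of 2-hydroxyethyl giving a 1.1-fold lower number from compound 2 to compound 4 (0.05 log units; within the scatter) and vinyl in place of 3-bromopropyl giving no change at the digits printed from compound 1 to compound 4 (within the scatter). Nothing available explains why these groups read alike.

On these data alone, whether an amine or a carboxylic acid on this oxygen would give a step beyond the scatter remains open.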